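The source may hold more compounds than are shown below. What is called first, only, known or untested is meant among the compounds shown, and "the series" means these compounds.

Compound 1 `Cc1cnc(Nc2ccc(Cl)cc2)nc1Nc1nc2ccccc2s1`: > 50000 nM
Compound 2 `Cc1ccc2nc(Nc3ccnc(Nc4ccc(S(C)(=O)=O)cc4)n3)sc2c1`: > 50000 nM

Both compounds were tested in a functional assay on PC-3 cells (Homo sapiens) for antiproliferative activity, read by MTT assay, with a stated time of 48 h; a higher number here means a weaker inhibitor, a lower number a stronger inhibitor. Compound 1 gives > 50000 nM, which is a limit of the assay rather than a number. Compound 2 likewise gives > 50000 nM, again a limit and not a number. Compound 1 therefore stands at the limit of > 50000 nM in this assay, at which 2 of the 2 values shown sit, with no numerical value that could place it against anything else in this assay.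

Compound 3 `Cc1cnc(Nc2ccc(F)cc2)nc1Nc1nc2ccccc2s1` has not yet been measured in this assay. It differs from compound 1 by fluoro in place of chloro on an aromatic carbon. Going by the values given here, no step between measured compounds is available, so the size of this change cannot be read from the data. Given that compound 1 sits at the limit of > 50000 nM in this assay, at which 2 of the 2 values shown sit, the change is expected to produce no step beyond the scatter in either direction, and the most likely outcome is that compound 3 is again reported only as a limit. The value of compound 3 in this assay is estimated at 60000 nM, with a range from 15000 nM to 200000 nM. The step this estimate means is expected to be a step that the limit leaves unreadable from compound 1 to compound 3.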

Compound 3, half-maximal inhibitory concentration: > 50000 nM
Compound 3 ended at the assay's limit; the forecaster's own chance of this, stated with the estimate: 80%; the middle value is on the limit's open side.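

Compound 1 and compound 3 are both reported only as limits in this assay, so no step can be read for fluoro in place of chloro: the limit of > 50000 nM in this assay, at which 3 of the 3 values shown sit.

The compounds shown leave open how compound 1 and compound 3 truly compare, and which structural change, if any, would bring a numerical value in this assay.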